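Hydroxymethyl in place of bromo on the shared core

The compounds below may be only part of what the source reports. "The series", "measured", "known", "first", "only" and "open" are said of these compounds alone.

Compound 1 `COc1ccc(Cn2c(C(=O)N3CCC(C(=O)NCc4cccc(Br)c4)CC3)cc3sccc32)cc1` gives > 100000 nM in an ADME assay on HEK-293T cells (Homo sapiens) for cytotoxicity, read by luminescence, with a stated time of 24 h (a lower number here means that less compound is tolerated, a higher number that more compound is tolerated), as a limit of the assay and not as a number. Compound 2 `CCCNC(=O)C1CCN(C(=O)c2cc3sccc3n2Cc2ccc(OC)cc2)CC1` gives 18800 nM in this assay and compound 3 `CCCNC(=O)C1CCN(C(=O)c2c(Br)c3sccc3n2Cc2ccc(OC)cc2)CC1` gives 31600 nM there. Compound 3 therefore stands alongside compound 2 on the numbers, the two lying within the scatter of each other.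

Compound 4 `CCCNC(=O)C1CCN(C(=O)c2c(CO)c3sccc3n2Cc2ccc(OC)cc2)CC1` has not yet been measured. Its difference from compound 3 is hydroxymethyl in place of bromo on an aromatic carbon and it places hydroxymethyl in place of bromo on an aromatic carbon of a five-membered aromatic ring with 1 nitrogen. The most relevant evidence concerns this same carbon, where bromo in place of hydrogen gave a 1.7-fold higher number from compound 2 to compound 3 (0.23 log units; within the scatter) and so made no change beyond the scatter. Ethyl in place of 3-bromophenyl gave an at least 5.3-fold lower number from compound 1 to compound 2 (0.72 log units; beyond the scatter) but lies at a different place in the molecule and offers little guidance for this carbon. The expected step is a 1.1-fold lower number from compound 3 to compound 4 (0.05 log units; within the scatter) and it is not expected to exceed the scatter. For compound 4 the estimated value is 28000 nM in this assay with an expected range from 11000 nM to 70000 nM as its span.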

Compound 4, half-maximal cytotoxic concentration: > 100000 nM
Compound 4: a limit, no number (the forecaster's own chance of this, stated with the estimate: 10%); at least 3.5-fold (0.55 log units) between middle value and limit.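

Among the compounds shown here, on this aromatic carbon of the five-membered aromatic ring with 1 nitrogen, the earlier compounds offered only bromo in place of hydrogen, a step within the scatter, so nothing yet showed that this position could move the result in this assay. Hydroxymethyl shows that it can: in place of bromo it gives an at least 3.1-fold higher number from compound 3 to compound 4 (0.50 log units; beyond the scatter), and in place of hydrogen it gives an at least 5.3-fold higher number from compound 2 to compound 4 (0.72 log units; beyond the scatter), so more compound is tolerated with hydroxymethyl here than with either of the other two groups. Compound 4 stands at a limit of the assay and not at a number, so the true size of both steps cannot be read: the limit of > 100000 nM in this assay, at which 2 of the 4 values shown sit.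

The compounds shown leave open whether the oxygen or the added carbon of hydroxymethyl carries the step, which a methyl, a methoxymethyl or an aminomethyl group or a carboxylic acid on this same carbon would help to separate. They also leave open whether hydroxymethyl acts the same way when the propyl amide gives way to the 3-bromobenzyl amide of compound 1.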